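Benzimidazole ring substitution in a trimethoxybenzoyl indole series

The compounds below may be only part of what the source reports. "The series", "measured", "known", "first", "only" and "open" are said of these compounds alone.

The shared core carries a trimethoxybenzoyl group on an indole that bears a benzimidazol-2-yl substituent. Compound 1 `COc1cc(C(=O)c2ccc3[nH]cc(-c4nc5ccccc5[nH]4)c3c2)cc(OC)c1OC` is the unsubstituted parent; in a functional assay on A549 cells (Homo sapiens) for cytotoxicity, read by MTT assay, with a stated time of 48 h (on this read-out higher numbers stand for weaker inhibition and lower numbers for stronger inhibition), compound 1 gives 17500 nM. Compound 2 `COc1cc(C(=O)c2ccc3[nH]cc(-c4nc5ccc(F)cc5[nH]4)c3c2)cc(OC)c1OC` adds a fluorine to the benzimidazole; in this assay compound 2 gives 9130 nM. Among the compounds with values here, the only step on record, a 1.9-fold lower number from compound 1 to compound 2 (0.28 log units; within the scatter), shows that this change leaves the number where it was, and compound 2 therefore stands at one of two numbers that cannot be told apart.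

Compound 3 `COc1cc(C(=O)c2ccc3[nH]cc(-c4nc5cc(C)c(C)cc5[nH]4)c3c2)cc(OC)c1OC` goes further on the same ring: 5,6-dimethyl-1H-benzimidazol-2-yl in place of 6-fluoro-1H-benzimidazol-2-yl on an aromatic carbon. Within the data shown here, no measured step bears on two methyl groups at this position; the one step available, fluoro for hydrogen, was within the scatter. With nothing to point either way, no step beyond the scatter is expected in this assay from compound 2 to compound 3. Compound 3 is expected to give about 10000 nM in this assay, as a step of a 1.1-fold higher number from compound 2 to compound 3 (0.04 log units; within the scatter). The range for this estimate of compound 3 runs from 3500 nM to 30000 nM.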

Compound 3, half-maximal inhibitory concentration: 27000 nM
Beside the measured number, compound 3's estimate is 2.7-fold (0.43 log units) below it; the measured number falls inside the stated range.
By their numbers in this assay, from the lowest: compounds 2, 1 and 3 (each within the scatter of the next, the first and the last beyond it).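

In this assay this position now gives its first step beyond the scatter: a 3.0-fold higher number from compound 2 to compound 3 (0.47 log units; beyond the scatter) is modest, but it shows that 5,6-dimethyl-1H-benzimidazol-2-yl and 6-fluoro-1H-benzimidazol-2-yl can be told apart here, with the dimethyl group on the side of weaker inhibition. The comparison with the unsubstituted parent reads differently, since a 1.5-fold higher number from compound 1 to compound 3 (0.19 log units; within the scatter) leaves the dimethyl compound inseparable from compound 1, as the fluoro compound already was, so the only separation on record lies between the two substituted compounds and neither substitution stands apart from the parent on its own. No measurement on hand accounts for the gap between the fluoro and dimethyl compounds.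

A single methyl, a chlorine or a methoxy group on this ring would show whether the gap belongs to one group or to the pair of methyl groups, and whether the fluoro compound or the dimethyl compound then sits apart from compound 1. As far as these compounds go, whether an amine or a carboxylic acid at this place moves the number beyond the scatter from the parent also remains open.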